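Halogen swap on the benzylidene arm of compound 3

The source may hold more compounds than are shown below. What is called first, only, known or untested is meant among the compounds shown, and "the series" means these compounds.

Compound 1 `COc1ccccc1/C=c1/[nH]c(=O)/c(=C\c2ccccc2OC)n(C)c1=O` and compound 2 `COc1ccccc1/C=c1/[nH]c(=O)/c(=C\c2cccc(Cl)c2Cl)[nH]c1=O` carry no number; in a functional assay on HeLa cells (Homo sapiens) for cytotoxicity, read by CCK-8 assay, with a stated time of 72 h (a lower number here means a stronger inhibitor, a higher number a weaker inhibitor), compound 1 is reported as "not active" (no number reported), and in this assay compound 2 is reported as "not active" (no number reported). Compound 3 `C=CCn1c(=O)/c(=C\c2ccccc2Cl)[nH]c(=O)/c1=C\c1ccccc1OC` is the only member of the series with a measured value: in this assay compound 3 gives 5100 nM, so it stands alone as the sole quantified point, and no comparison within the scatter is possible from the numbers shown.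

Compound 4 `C=CCn1c(=O)/c(=C\c2cc(Br)ccc2F)[nH]c(=O)/c1=C\c1ccccc1OC` differs from compound 3 by 5-bromo-2-fluorophenyl in place of 2-chlorophenyl on a double-bonded chain carbon bound to an aromatic carbon. Within the data shown here, no measured pair covers a change of this kind, so the direction is open. The halogen pattern on the aryl group shifts, but nothing in the series shows what such a shift does to the read-out. The expectation is a step from compound 3 to compound 4 of a 1.0-fold lower number from compound 3 to compound 4 (0.01 log units; within the scatter), that is, none beyond the scatter. On that basis compound 4 is expected to give about 5000 nM in this assay, with a likely range from 1500 nM to 16000 nM, and a fair chance of no number at all, as seen for compound 1 and compound 2.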

Compound 4, half-maximal inhibitory concentration: 34600 nM
Compound 4: the middle estimate sits 6.9-fold (0.84 log units) below what was measured, outside the stated range (above it).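

In this assay, among these compounds, the first measured step at this position is a 6.8-fold higher number from compound 3 to compound 4 (0.83 log units; beyond the scatter), so the double-bonded chain carbon bound to an aromatic carbon carries an aryl group whose halogen pattern matters to the read-out, and the change from 2-chlorophenyl to 5-bromo-2-fluorophenyl weakens the compound while still leaving a measurable value. The swap removes chlorine and brings in both fluorine and bromine, so this single step cannot assign the loss to either halogen. Nothing available explains the loss in strength.

Open, going by these compounds, is whether 2-fluorophenyl or 3-bromophenyl alone would match compound 3 or compound 4. Also open, on these data alone, is how an amine or a carboxylic acid in place of the halogens on this aryl group would affect the read-out.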